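Chloro placement on the indazole of compound 2

The source may hold more compounds than are shown below. What is called first, only, known or untested is meant among the compounds shown, and "the series" means these compounds.

Two compounds of this series are measured. In a functional assay on MCF7 cells (Homo sapiens) for cytotoxicity, read by CellTiter-Glo, with a stated time of 5 days (a higher number here means a weaker inhibitor, a lower number a stronger inhibitor), compound 1 `CC/C(=C(/c1ccc(/C=C/C(=O)O)cc1)c1cc2cn[nH]c2cn1)c1ccccc1` gives 442 nM, and compound 2 `CC/C(=C(/c1ccc(/C=C/C(=O)O)cc1)c1ccc2[nH]nc(Cl)c2c1)c1ccccc1` gives 284 nM, the lowest of the two numbers; the step of a 1.6-fold lower number from compound 1 to compound 2 (0.19 log units; within the scatter) stays within the scatter. Compound 3 `CC/C(=C(/c1ccc(/C=C/C(=O)O)cc1)c1ccc2[nH]ncc2c1Cl)c1ccccc1` carries 4-chloro-1H-indazol-5-yl in place of 3-chloro-1H-indazol-5-yl on a double-bonded chain carbon bound to an aromatic carbon and a double-bonded chain carbon. Going by the values given here, no measured step concerns moving the chlorine on the indazole, and the one step known is itself within the scatter, so in this assay no change beyond the scatter is expected, that is a 1.1-fold higher number from compound 2 to compound 3 (0.02 log units; within the scatter). Compound 3 is therefore estimated at 300 nM, within 120 nM to 900 nM.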

Compound 3, half-maximal inhibitory concentration: 1.6 nM
Beside the measured number, compound 3's estimate is 190-fold (2.27 log units) above it, outside the stated range (below it).
By their numbers in this assay, from the lowest: compound 3; then compounds 2 and 1 (each within the scatter of the next).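

The place of the chlorine decides the result here: with the same atoms and counts, 4-chloro-1H-indazol-5-yl in place of 3-chloro-1H-indazol-5-yl gives a 180-fold lower number from compound 2 to compound 3 (2.25 log units; beyond the scatter) in this assay. The wider replacement gives a 280-fold lower number from compound 1 to compound 3 (2.44 log units; beyond the scatter) at the same double-bonded chain carbon, so the earlier within-scatter step gave no sign of this sensitivity. Nothing available bears on the origin of this difference.

Open, going by these compounds, is whether a fluorine or a methyl group in place of the chlorine of 4-chloro-1H-indazol-5-yl would keep so low a number. Also open, on these data alone, is whether the acrylic acid chain of compound 3 contributes to it.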